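A Methyl Branch on the Ester Chain of Two Cores

The source may report more compounds than this note shows. Statements on the series, on what has been measured and on what is new or still open speak of the compounds shown alone.

Compound 1 `CCCOC(=O)C1=C(C)NC(=O)NC1c1cccs1`: 32%
Compound 2 `CC1=C(C(=O)OCC(C)C)C(c2cccs2)NC(=O)N1`: 11%
Compound 3 `CCCOC(=O)C1=C(C)NC(=S)NC1c1ccsc1`: 1%

All three were tested in an assay on membranes from HeLa cells for displacement of a labelled ligand from adenosine receptor A3 (Homo sapiens), read by scintillation counting, with a stated time of 180 min, tested at 1 uM; a higher number here means more inhibition at the concentration tested (going by the name of the read-out), a lower number less inhibition. Compound 1 carries a straight ester chain; compound 2 has the same core with methyl in place of hydrogen on a saturated chain carbon bound to two saturated chain carbons. That change gave a number 21 percentage points lower from compound 1 to compound 2 (beyond the scatter).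

Compound 3 has a different core from compound 1; the difference between the two cores is not broken down here. In this assay compound 3 gives 1%, the lowest of the three numbers, within the scatter of compound 2 and beyond the scatter of compound 1.

Compound 4 `CC1=C(C(=O)OCC(C)C)C(c2ccsc2)NC(=S)N1` is built from compound 3 by the same change, (methyl in place of hydrogen on a saturated chain carbon bound to two saturated chain carbons). On the core of compound 1 this change lowered the read-out by a modest step. On the core of compound 3 there is little room for a further fall, because compound 3 already gives 1%. The step of a number 1 percentage points higher from compound 3 to compound 4 (within the scatter) is therefore expected to be small and within the scatter. Compound 4 is expected to give about 2%, with the range -10% to 14%.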

Compound 4, a percentage reported as inhibition, at one concentration (the size of the read-out at that concentration, not a potency): 2%
For compound 4 middle estimate and measured number coincide at the digits printed; the measured number falls inside the stated range.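

Going from propyl to isobutyl on the ester chain gave a number 1 percentage points higher from compound 3 to compound 4 (within the scatter) in this assay. The same change therefore did not carry over from one core to the other with the same size: the same change on two cores in this assay, a number 21 percentage points lower (beyond the scatter) from compound 1 to compound 2 and a number 1 percentage points higher (within the scatter) from compound 3 to compound 4, 22 percentage points apart, beyond the scatter of two such steps

This does not show that the core sets the size of the step, since compound 3 already stands at 1%, which leaves almost no room for a fall like the earlier one to appear. Within the data shown here, the two pairs show only that a step seen on one core cannot simply be assumed on another in this small series.

The compounds shown leave open how a longer chain, such as a pentyl ester, or a ring at the end of the chain, such as a cyclopropylmethyl ester, would read in this assay. They also leave open what a carboxylic acid or an amide in place of the ester would do on either core.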